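The source may hold more compounds than are shown below. What is called first, only, known or untested is meant among the compounds shown, and "the series" means these compounds.

Compound 1 `Nc1nc2cc(-c3nn(CCCCCC(=O)NO)c4ncnc(N)c34)ccc2o1` carries a hydroxamic acid on a chain attached to an aromatic nitrogen of its core, and in a functional assay on SNU-423 cells (Homo sapiens) for inhibition, read by MTT assay, with a stated time of 72 h (on this read-out lower numbers stand for stronger inhibition and higher numbers for weaker inhibition), compound 1 gives 12600 nM. Two related compounds share the same chain-linked hydroxamic acid but a different aromatic group on the core: compound 2 `Nc1ncnc2c1c(-c1cnc3[nH]ccc3c1)nn2CCCCCC(=O)NO`, for which the entry reads "not determined" (no result reported), and compound 3 `Nc1ncnc2c1c(-c1cnc3[nH]ccc3c1)nn2CCCCCCCCC(=O)NO`, which in this assay gives 7500 nM. Compound 1 thus stands at the higher of the two numbers, though its difference from compound 3 lies within the usual scatter of this assay, so no order between them can be claimed.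

Compound 4 `Nc1nc2cc(-c3nn(CCCCC(=O)NO)c4ncnc(N)c34)ccc2o1` differs from compound 1 in one place: hydroxycarbamoyl in place of (hydroxycarbamoyl)methyl on a saturated chain carbon, four bonds along the chain from an aromatic nitrogen. The chain toward the hydroxamic acid is one carbon shorter. Going by the values given here, no measured pair shows the effect of such a change, and the two measured compounds differ elsewhere. The step from compound 1 to compound 4 is therefore expected to be small, a 1.2-fold higher number from compound 1 to compound 4 (0.08 log units; within the scatter), in no clear direction beyond the scatter. Compound 4 is expected to give about 15000 nM, between 6000 nM and 40000 nM.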

Compound 4, half-maximal inhibitory concentration: 3030 nM
The estimate for compound 4 lay 5.0-fold (0.69 log units) above the measured number, and the stated range ends above it.
By their numbers in this assay, from the lowest: compound 4; then compounds 3 and 1 (each within the scatter of the next).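

Going by these compounds alone, this is the first measured pair that differs in the chain alone. In this assay, hydroxycarbamoyl in place of (hydroxycarbamoyl)methyl on a saturated chain carbon, four bonds along the chain from an aromatic nitrogen, brings a 4.2-fold lower number from compound 1 to compound 4 (0.62 log units; beyond the scatter) on the core of compound 1. Chain length at this position therefore matters here, since removing one carbon while keeping the hydroxamic acid moves the number beyond the scatter, although nothing at hand explains the step.

On these data alone, whether a still shorter chain ending in 2-(hydroxycarbamoyl)ethyl would continue this trend remains open. Also open, as far as these compounds go, are whether the same shortening would act alike on the compounds with the other aromatic group, and whether a carboxylic acid could stand in for the hydroxamic acid at the chain end.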